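A few compounds are considered here, and "the series" means these few. Any claim that something is new, unique, unknown or untested is made for them only; others in the source may bear on it.

Working notes on the series. In a functional assay (aorta) with Rattus norvegicus as the target (a lower number here means that less compound is needed, a higher number that more compound is needed for the effect), compound 1 (`N#CCC/N=C(\S)C1=CC(CF)(CF)Oc2ccc([N+](=O)[O-])cc21`) gives 0.141 nM and compound 2 (`CC1(CF)C=C(C(=O)NCCC#N)c2cc([N+](=O)[O-])ccc2O1`) gives 3.98 nM. Compound 2 therefore holds the higher of the two numbers, and its gap to compound 1 lies beyond the usual scatter.

Compound 3 (`N#CCCNC(=O)C1=CC(CF)(CF)Oc2ccc([N+](=O)[O-])cc21`) has not yet been measured. It differs from compound 2 in one place: fluoro in place of hydrogen on a saturated chain carbon bound to a saturated ring carbon. This difference also reads as methyl to fluoromethyl.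

Within the data shown here, no pair of measured compounds shows this change, so the series offers no step to carry over. In this assay, no step beyond the scatter is expected in either direction. The expectation starts from compound 2 at 3.98 nM, and the range is kept wide for lack of any precedent. The estimated step is a 1.3-fold lower number from compound 2 to compound 3 (0.12 log units; within the scatter). For compound 3, the estimated value is 3 nM, with an expected range of 0.5 nM to 18 nM.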

Compound 3, half-maximal effective concentration: 2.24 nM
Estimate against measurement, compound 3: 1.3-fold (0.13 log units) above; low and high end bracket the measured number.
By their numbers in this assay, from the lowest: compound 1; then compounds 3 and 2 (each within the scatter of the next).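

In this assay the change of fluoro in place of hydrogen on a saturated chain carbon bound to a saturated ring carbon, which also reads as methyl to fluoromethyl, gives a 1.8-fold lower number from compound 2 to compound 3 (0.25 log units; within the scatter) and so has no effect that can be told from the scatter at this position. The new compound also opens a second one-place comparison on a double-bonded ring carbon, where the group of 7 heavy atoms holding oxygen stands in place of the group of 7 heavy atoms holding sulfur, and there the result is a 16-fold higher number from compound 1 to compound 3 (1.20 log units; beyond the scatter) and thus a change that counts for far more in this series than the fluoro change. No data are at hand that would account for either step.

The compounds shown carry the sulfur-holding group only together with two fluoromethyl groups, so it remains open whether its step stays the same in the presence of a plain methyl. In this assay, from the compounds shown here alone, it also remains open how a trifluoromethyl, a chloromethyl or a longer chain would read at the place of the fluoromethyl.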